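Shortening the chain: from compound 2 to compound 4

The compounds below may be only part of what the source reports. "The series", "measured", "known", "first", "only" and "open" are said of these compounds alone.

Measured in a functional assay on MDA-MB-231 cells (Homo sapiens) for inhibition, read by MTT assay, with a stated time of 72 h; a higher number here means a weaker inhibitor, a lower number a stronger inhibitor:
- compound 1 `Nc1ncnc2c1c(-c1cnc3[nH]ccc3c1)nn2CC(=O)NO` gives > 150000 nM as a limit
- compound 2 `Nc1ncnc2c1c(-c1cnc3[nH]ccc3c1)nn2CCCCCCCCC(=O)NO` gives 11000 nM as a number
- compound 3 `Nc1ncnc2c1c(-c1cnc3[nH]ccc3c1)nn2CCCCCCCCCC(=O)NO` gives 10100 nM as a number

Compound 2 sits level with compound 3 on these numbers. For the measured compounds named here, the one measured step between numbers is a 1.1-fold lower number from compound 2 to compound 3 (0.04 log units; within the scatter) and stays within the scatter, so it gives no size for a large cut in the chain. Compound 4 `Nc1ncnc2c1c(-c1cnc3[nH]ccc3c1)nn2CCC(=O)NO` is reached by hydroxycarbamoyl in place of 6-(hydroxycarbamoyl)hexyl on a saturated chain carbon, two bonds along the chain from an aromatic nitrogen, in words hydroxycarbamoyl in place of 6-(hydroxycarbamoyl)hexyl on a saturated chain carbon, two bonds along the chain from an aromatic nitrogen. The expectation of weaker inhibition rests on compound 1 , the measured compound with the shortest chain, which gives > 150000 nM as a limit. An expected step of a 7.3-fold higher number from compound 2 to compound 4 (0.86 log units; beyond the scatter) in this assay is estimated, toward a higher number and beyond the scatter. For compound 4 the estimated value is 80000 nM, with an expected range of 25000 nM to 150000 nM and a real chance of only a limit being reported.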

Compound 4, half-maximal inhibitory concentration: > 150000 nM
Compound 4: a limit, no number; the forecaster's own chance of this, stated with the estimate: 50%; at least 1.8-fold (0.27 log units) between middle value and limit.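

Cutting 6-(hydroxycarbamoyl)hexyl back to hydroxycarbamoyl on this saturated chain carbon gives the first readable size for a large cut in the chain in this assay, where the step is an at least 13-fold higher number from compound 2 to compound 4 (1.13 log units; beyond the scatter). Compound 4 gives > 150000 nM, a limit and not a number. The step from compound 1 to compound 4 cannot be read, and the two shortest chains shown stand together at one limit: the limit of > 150000 nM in this assay, at which 2 of the 4 values shown sit.

Still open, going by these compounds, is which chain length, from that of compound 4 up to that of compound 2, first gives a number in this assay, and whether a longer chain than in compound 3 changes that number. Also open, on these data alone, is whether a carboxylic acid in place of hydroxycarbamoyl on the long chain keeps any of the inhibition.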